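Ester in place of the anilide on the pyrrole carbonyl

The compounds below may be only part of what the source reports. "The series", "measured", "known", "first", "only" and "open" are said of these compounds alone.

Among the compounds with values here, compound 2 `CCn1c(C(=O)N(C)c2ccccc2)ccc1C(CC)(CC)c1ccc(OCC(O)C(C)(C)C)c(C)c1` holds the highest of the two numbers so far in an assay on HL-60 cells for agonist activity at vitamin D3 receptor (Homo sapiens), read by microscopy, with a stated time of 96 h; a higher number here means that more compound is needed for the effect, a lower number that less compound is needed: compound 2 gives 6400 nM, while compound 1 `CC[C@@H](C)[C@H](NC(=O)c1ccc(C(CC)(CC)c2ccc(OCC(O)C(C)(C)C)c(C)c2)n1CC)C(=O)OC` gives 26 nM. Within the data shown here, the one measured step, a 250-fold higher number from compound 1 to compound 2 (2.39 log units; beyond the scatter), came from exchanging the amide substituent on the carbonyl carbon and shows that this position moves the read-out strongly. Compound 3 `C#CC(C)OC(=O)c1ccc(C(CC)(CC)c2ccc(OCC(O)C(C)(C)C)c(C)c2)n1CC` carries the change ((1-methylprop-2-yn-1-yl)oxy in place of methyl(phenyl)amino on a carbonyl carbon), so the same carbonyl carbon is again altered, now to an ester. Among the measured compounds shown here, no measured pair shows an ester at this place; the only step that bears on it is the large one between compound 1 and compound 2, which tells that variation here is consequential but not in which direction an ester goes. For compound 3 the expectation is a lower number than compound 2, the estimated step being a 21-fold lower number from compound 2 to compound 3 (1.33 log units; beyond the scatter). The estimate for compound 3 is 300 nM, with a range from 30 nM to 3000 nM.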

Compound 3, half-maximal effective concentration: 200 nM
Beside the measured number, compound 3's estimate is 1.5-fold (0.18 log units) above it, within the range that was stated.
By their numbers in this assay, from the lowest: compound 1; then compound 3; then compound 2.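

In this assay, an ester on this carbonyl carbon gives a far lower number than the anilide (a 32-fold lower number from compound 2 to compound 3 (1.51 log units; beyond the scatter)), so an amide link is not needed here for a number well under that of compound 2. The ester does not match the amide of compound 1 (a 7.7-fold higher number from compound 1 to compound 3 (0.89 log units; beyond the scatter)), which places the two amides on either side of the ester: among these three compounds, amide versus ester alone does not decide the order, and the substituent carried by the link counts as well. Nothing available explains either step.

Open, going by these compounds, is how a plain methyl ester or the free carboxylic acid would read on this carbonyl carbon. Also open, on these data alone, is whether the triple bond of the (1-methylprop-2-yn-1-yl)oxy group contributes, which an ester with a saturated butyl chain would test.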